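This account rests on a few compounds, and the source may have more. Where it says the series, first, only, none or still open, it means among the compounds named here.

Working notes on the series. The shared core of compound 1, `C[C@@H]1CC[C@@H](Oc2cc(Br)ccn2)CN1C(=O)c1ccccc1-n1nccn1`, carries a 4-bromopyridin-2-yl ether on the saturated ring. In a functional assay on CHO-K1 cells for antagonist activity at Orexin receptor type 2 (Homo sapiens), read by FLIPR and calcium flux (on this read-out lower numbers stand for stronger inhibition and higher numbers for weaker inhibition), compound 1 gives 10 nM. Compound 2, `C[C@@H]1CC[C@@H](Oc2cc(C#N)ccn2)CN1C(=O)c1ccccc1CC(F)(F)F`, exchanges both the ether group and the amide aryl substituent; in this assay compound 2 gives 32 nM. Compound 3, `C[C@@H]1CC[C@@H](Oc2ccccn2)CN1C(=O)c1ccccc1-n1nccn1`, keeps the triazolyl benzamide and carries an unsubstituted pyridin-2-yl ether; for compound 3 the entry in this assay reads "not determined" (no result reported). Of the two numbers shown, compound 1 has the lowest, and the gap to compound 2 lies beyond the scatter, though the two differ in more than one place, so no single-point step can be read from them.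

Compound 4, `Cc1cccc(O[C@@H]2CC[C@@H](C)N(C(=O)c3ccccc3-n3nccn3)C2)n1`, is the next target. Against compound 1 the change is 6-methylpyridin-2-yl in place of 4-bromopyridin-2-yl on an oxygen on a saturated carbon. Among the compounds with values here, no measured step of this kind exists in the set, so the expectation rests on compound 1 alone. Given that compound 1 gives 10 nM, the step from compound 1 to compound 4 is expected to be small and toward weaker inhibition, likely within or just beyond the scatter, namely a 2.5-fold higher number from compound 1 to compound 4 (0.40 log units; beyond the scatter). Compound 4 is therefore estimated at 25 nM in this assay, with a range from 7 nM to 90 nM.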

Compound 4, half-maximal inhibitory concentration: 33 nM
Compound 4: the middle estimate sits 1.3-fold (0.12 log units) below what was measured; the measured number falls inside the stated range.
By their numbers in this assay, from the lowest: compound 1; then compounds 2 and 4 (each within the scatter of the next).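

Within the data shown here, this is the first step that can be read at a single place: with the triazolyl benzamide unchanged, exchanging the group on an oxygen on a saturated carbon gives, in this assay, a 3.3-fold higher number from compound 1 to compound 4 (0.52 log units; beyond the scatter), so inhibition at this position responds to the pyridine substitution pattern. The response is modest, and it arises although 4-bromopyridin-2-yl and 6-methylpyridin-2-yl match in their counts of heavy atoms, hydrogen-bond donors and hydrogen-bond acceptors, so those counts alone do not capture the difference between the two groups. No measurement at hand bears on why the number moves in this direction.

The step joins two changes, bromine to methyl and the numbered place of the substituent on the pyridine, and these cannot be separated here; steps involving compound 2 or compound 3 cannot be read, which leaves the unsubstituted pyridin-2-yl ether of compound 3 without a number as a reference point. Going by these compounds, how a methoxy group or an amine on the pyridine would read in this assay also remains open.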